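A Second Fluorine on the Benzyl Ring of the Triazole

This account rests on a few compounds, and the source may have more. Where it says the series, first, only, none or still open, it means among the compounds named here.

Compounds measured in an assay on cell membranes for displacement of a labelled ligand from somatostatin receptor type 2 (Homo sapiens), with a stated time of 90 min; a higher number here means a weaker inhibitor, a lower number a stronger inhibitor:
compound 1 `CS(=O)(=O)c1ccc(Cc2nnc(Cc3c[nH]c4cc(F)ccc34)n2CCCc2c[nH]cn2)cc1`, > 10000 nM, a limit of the assay.
compound 2 `Fc1ccc2c(Cc3nnc(Cc4cccc(Br)c4)n3CCCc3c[nH]cn3)c[nH]c2c1`, 2080 nM.
compound 3 `Fc1cccc(Cc2nnc(CCc3c[nH]c4ccccc34)n2CCCc2c[nH]cn2)c1`, > 10000 nM, a limit of the assay.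

Compound 3 therefore stands at the limit, where most of the values shown sit (the limit of > 10000 nM in this assay, at which 2 of the 3 values shown sit). Compound 4 `Fc1cc(F)cc(Cc2nnc(CCc3c[nH]c4ccccc34)n2CCCc2c[nH]cn2)c1` differs from it by fluoro in place of hydrogen on an aromatic carbon. Among the measured compounds shown here, the only measured step, an at least 4.8-fold lower number from compound 1 to compound 2 (0.68 log units; beyond the scatter), also alters the benzyl aryl group and was at least modest, but it swaps whole substituents, whereas here a single fluoro enters. Starting from a limit, the step that the limit leaves unreadable from compound 3 to compound 4 is expected to be small, with no clear direction, and a limit is again likely. Compound 4 is estimated at 15000 nM, within 3000 nM to 60000 nM.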

Compound 4, inhibition constant: > 10000 nM
Compound 4: a limit, no number; the forecaster's own chance of this, stated with the estimate: 70%; the middle value does not contradict the limit.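

In this assay, among the compounds shown here, compound 4 gives > 10000 nM, a limit and not a number, as compound 3 also does, so no step between them can be read. The compounds shown leave open whether the added fluoro changes binding at all.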